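The compounds below may be only part of what the source reports. "The series", "measured", "known", "first", "only" and "open" are said of these compounds alone.

Compound 3, `COc1ccc(CN(C(=O)CSc2nc3ccccc3s2)c2cc(OC)c(OC)c(OC)c2)cc1C`, gives 34300 nM in a functional assay on PC-3 cells (Homo sapiens) for antiproliferative activity, read by MTT assay, with a stated time of 48 h (a lower number here means a stronger inhibitor, a higher number a weaker inhibitor), the highest number among the three compounds measured. Compound 2, `COc1ccc(CN(C(=O)CSc2nc3ccccc3s2)c2cc(OC)c(OC)c(OC)c2)cc1F`, gives 20100 nM, and the step of a 1.7-fold higher number from compound 2 to compound 3 (0.23 log units; within the scatter) lies within the scatter. Going by the values given here, compound 1, `COc1ccc2nc(SCC(=O)N(Cc3ccc(OC)c(O)c3)c3cc(OC)c(OC)c(OC)c3)sc2c1`, gives 4110 nM; it differs from compound 3 in two places, so no single step connects them, but the gap between their two values is beyond the scatter.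

Compound 4, `COc1ccc(CN(C(=O)CSc2nc3ccccc3s2)c2cc(OC)c(OC)c(OC)c2)cc1O`, arises from compound 3 by the change (hydroxy in place of methyl on an aromatic carbon). Among the compounds with values here, the only measured step on this benzyl ring, from fluoro to methyl, bore on a different group and stayed within the scatter, so it sets no direction for the present change. Compound 1, which carries the same hydroxy on this ring, shows that a hydroxy-bearing analogue can reach a markedly lower number, though its second difference clouds the comparison. Compound 4 is therefore expected to give a lower number than compound 3, with the step of a 3.8-fold lower number from compound 3 to compound 4 (0.58 log units; beyond the scatter) estimated. The estimate for compound 4 in this assay is 9000 nM, with a range from 3000 nM to 27000 nM.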

Compound 4, half-maximal inhibitory concentration: 2110 nM
Beside the measured number, compound 4's estimate is 4.3-fold (0.63 log units) above it; measured number below the stated range.
By their numbers in this assay, from the lowest: compounds 4 and 1 (each within the scatter of the next); then compounds 2 and 3 (each within the scatter of the next).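

In this assay, the group at this position on the benzyl ring now makes a clear difference: the change from methyl to hydroxy gives a 16-fold lower number from compound 3 to compound 4 (1.21 log units; beyond the scatter), and the change from fluoro to hydroxy gives a 9.5-fold lower number from compound 2 to compound 4 (0.98 log units; beyond the scatter). The hydroxy-bearing compound 1 also now has a comparison that differs in one place, and a 1.9-fold lower number from compound 1 to compound 4 (0.29 log units; within the scatter) shows that the extra methoxy on its core has no readable effect here. Nothing in the available evidence accounts for the effect of the hydroxy.

As far as these compounds go, it remains open whether an amine or a carboxylic acid at this position would match the hydroxy. Also open is whether the hydroxy would have the same effect without the neighbouring methoxy group, which all the compounds shown carry.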